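Hydrogen for methyl on sulfur: another limit expected

The source may hold more compounds than are shown below. What is called first, only, known or untested is meant among the compounds shown, and "the series" means these compounds.

Of the compounds shown here, three of one shared core have been tested in a functional assay on CCRF-CEM cells (Homo sapiens) for cytotoxicity, read by MTT assay, with a stated time of 72 h; a higher number here means that more compound is tolerated, a lower number that less compound is tolerated. Compound 1 `COc1ccc(CNc2nc([SeH])nc3ccccc23)cc1` returns only a limit of the assay, > 100000 nM. Compound 2 `Sc1nc(NCc2ccccc2)c2ccccc2n1` likewise returns only a limit, > 100000 nM. Compound 3 `COc1ccc(CNc2nc(SC)nc3ccccc23)cc1`, the starting point here, also returns only a limit, > 100000 nM. Compound 3 therefore stands where every value shown stands, at the limit of > 100000 nM in this assay, at which 3 of the 3 values shown sit, and no ordering among the three compounds can be drawn. Going by the values given here, the one step between measured compounds that differ in a single place, a step that the two limits leave unreadable from compound 1 to compound 3, is unreadable for the same reason.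

Compound 4 `COc1ccc(CNc2nc(S)nc3ccccc23)cc1` differs from compound 3 by hydrogen in place of methyl on a sulfur. Among the compounds with values here, no measured step bears readably on this change. Since all three measured values sit at the limit, nothing points to a step in this assay beyond the usual scatter. Compound 4 is therefore expected to return a limit as well, estimated at 100000 nM with a range from 50000 nM to 200000 nM. The step this expectation means, a number no higher from compound 3 to compound 4 (the limit leaves the size open), is expected to be nil.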

Compound 4, concentration lethal to 50% of the cells: 71600 nM
Compound 4: the middle estimate sits 1.4-fold (0.15 log units) above what was measured, within the range that was stated.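

Going by these compounds alone, compound 4, with its free sulfanyl on the aromatic carbon, gives the only number in this assay rather than a limit, so a change at this sulfur can bring a compound of this series within the range of the assay. Methylsulfanyl to sulfanyl reads as an at least 1.3-fold lower number from compound 3 to compound 4 (0.14 log units; that floor lies within the scatter), methoxy in place of hydrogen on an aromatic carbon reads as an at least 1.3-fold lower number from compound 2 to compound 4 (0.14 log units; that floor lies within the scatter), and one sulfur atom in place of one selenium atom reads as an at least 1.3-fold lower number from compound 1 to compound 4 (0.14 log units; that floor lies within the scatter). Each of these is only a floor, and compound 4 stands alone with a number: the limit of > 100000 nM in this assay, at which 3 of the 4 values shown sit.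

On these data alone, the true size of all three steps stays open. So does the effect in this assay of a longer chain on the sulfur, or of an amine or a carboxylic acid in its place.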